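Working notes: from compound 3 to compound 4

This account rests on a few compounds, and the source may have more. Where it says the series, first, only, none or still open, it means among the compounds named here.

Values in a functional assay on MCF7 cells (Homo sapiens) for inhibition, read by MTT assay, with a stated time of 3 days; a higher number here means a weaker inhibitor, a lower number a stronger inhibitor:
- compound 1 `CC[C@H](C)[C@H](NCC(=O)NNC(=O)COc1ccc(-c2nc3ccccc3s2)cc1OC)C(=O)O`: 1710 nM
- compound 2 `COc1cc(-c2nc3ccccc3s2)ccc1OCC(=O)NNC(=O)CN1CCC[C@H]1C(=O)O`: 840 nM
- compound 3 `CCOC(=O)[C@@H](NCC(=O)NNC(=O)COc1ccc(-c2nc3ccccc3s2)cc1OC)[C@@H](C)CC`: 1950 nM

Compound 3 is level with compound 1, with a 1.1-fold higher number from compound 1 to compound 3 (0.06 log units; within the scatter). Compound 2 has the lower number, with a 2.3-fold higher number from compound 2 to compound 3 (0.37 log units; beyond the scatter). Compound 4 `CCOC(=O)[C@H](CS)N(CC(=O)NNC(=O)COc1ccc(-c2nc3ccccc3s2)cc1OC)C(C)=O` brings this change: acetyl(1-(ethoxycarbonyl)-2-sulfanylethyl)amino in place of (1-(ethoxycarbonyl)-2-methylbutyl)amino on a saturated chain carbon bound to a carbonyl carbon. Exchanges of this group have so far given modest steps, such as a 2.0-fold lower number from compound 1 to compound 2 (0.31 log units; beyond the scatter). For the measured compounds named here, no measured compound carries the acetyl or sulfanyl features, so the direction remains open. An estimated 1.1-fold lower number from compound 3 to compound 4 (0.06 log units; within the scatter) is expected in this assay, with little confidence in its sign. For compound 4 the estimated value is 1700 nM, with an expected range of 700 nM to 4000 nM.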

Compound 4, half-maximal inhibitory concentration: 1890 nM
Compound 4: the middle estimate sits 1.1-fold (0.05 log units) below what was measured; the range from low to high includes it.
By their numbers in this assay, from the lowest: compound 2; then compounds 1, 4 and 3 (each within the scatter of the next).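

In this assay, the change to acetyl(1-(ethoxycarbonyl)-2-sulfanylethyl)amino gives no readable shift, with a 1.0-fold lower number from compound 3 to compound 4 (0.01 log units; within the scatter), and the same holds against the free acid, with a 1.1-fold higher number from compound 1 to compound 4 (0.04 log units; within the scatter). For the compounds shown here, only compound 2 stands apart, with a 2.3-fold higher number from compound 2 to compound 4 (0.35 log units; beyond the scatter), so 2-carboxypyrrolidin-1-yl remains the one group at this place set off from the others. No measured data bear on the reason for this result.

Acetyl and sulfanyl enter together, so their separate contributions cannot be read. Also open, on these data alone, is whether an amine or a longer chain at this place would match compound 2.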